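The source may report more compounds than this note shows. Statements on the series, on what has been measured and on what is new or still open speak of the compounds shown alone.

Three compounds share one core and differ only in the aryl group attached to a saturated ring carbon. Compound 1 `CC(=O)N1N=C(c2ccc3ccccc3c2)OC1c1cccc(Br)c1` gives 2.34 ug/mL in a functional assay on MCF7 cells (Homo sapiens) for antiproliferative activity, read by MTT assay, with a stated time of 48 h; on this read-out lower numbers stand for stronger inhibition and higher numbers for weaker inhibition; compound 2 `CC(=O)N1N=C(c2ccc3ccccc3c2)OC1c1ccc(Cl)cc1` gives 2.63 ug/mL in this assay; compound 3 `CC(=O)N1N=C(c2ccc3ccccc3c2)OC1c1ccccc1O` gives 2.12 ug/mL in this assay. Compound 2 sits at the upper end of these three numbers, yet the steps of a 1.1-fold higher number from compound 1 to compound 2 (0.05 log units; within the scatter) and a 1.2-fold lower number from compound 2 to compound 3 (0.09 log units; within the scatter) show that its gaps to the other two lie within the scatter, as does a 1.1-fold lower number from compound 1 to compound 3 (0.04 log units; within the scatter). Compound 4 `CC(=O)N1N=C(c2ccc3ccccc3c2)OC1c1ccc(C)cc1` has not yet been measured. It differs from compound 2 by methyl in place of chloro on an aromatic carbon. For the measured compounds named here, none of the measured steps exchanges a single substituent on the aryl ring in this way; all three replace the whole aryl group, and none of them moves beyond the scatter. On that basis the expected step is a 1.0-fold lower number from compound 2 to compound 4 (0.00 log units; within the scatter), no larger than the scatter allows. Compound 4 is therefore estimated at 2.6 ug/mL in this assay, within a range from 1.3 ug/mL to 5.2 ug/mL.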

Compound 4, half-maximal inhibitory concentration: 2.9 ug/mL
The estimate for compound 4 lay 1.1-fold (0.05 log units) below the measured number, and the stated range covers the measured number.
By their numbers in this assay, from the lowest: compounds 3, 1, 2 and 4 (each within the scatter of the next).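

In this assay, for the compounds shown here, the first exchange of a single substituent, on the aromatic carbon para to a large group, gives a 1.1-fold higher number from compound 2 to compound 4 (0.04 log units; within the scatter) and so stays as small as the replacements of the whole aryl group. The comparisons with the other two aryl groups, a 1.4-fold higher number from compound 3 to compound 4 (0.14 log units; within the scatter) and a 1.2-fold higher number from compound 1 to compound 4 (0.09 log units; within the scatter), also stay within the scatter, so 4-methylphenyl joins the three earlier aryl groups without separating from any of them. No supporting measurement is available to explain why these numbers stay so close.

On these data alone, it remains open whether an amine, a carboxylic acid or a longer chain at this para position would move the number beyond the scatter. The compounds shown also leave open whether any change to the shared core itself would do so.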